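The compounds below may be only part of what the source reports. "The series", "measured", "known", "first", "only" and "open" are said of these compounds alone.

In an ADME assay on the whole organism (plasma, strain 129/SvEvBrd x C57BL/6) for pharmacokinetics, with Mus musculus as the target, at a dose of 10 mg/kg by the oral route (on this read-out higher numbers stand for higher exposure at the dose given and lower numbers for lower exposure), compound 1 (`CC(=O)c1cccc([C@@H](O)[C@H](O)[C@H](O)CO)n1`) gives 10500 ng.h/mL and compound 2 (`CC(=O)c1nc([C@@H](O)[C@H](O)[C@H](O)CO)cn1C`) gives 10000 ng.h/mL. Compound 3 (`CC(=O)c1nc([C@@H](O)[C@H](O)[C@H](O)CO)c(C)[nH]1`) stands lowest of the three at 2640 ng.h/mL, beyond the scatter from both of the others. Compound 4 (`CCc1[nH]c(C(C)=O)nc1[C@@H](O)[C@H](O)[C@H](O)CO`) departs from compound 3 by a single change: methyl in place of hydrogen on a saturated chain carbon bound to an aromatic carbon, which turns methyl into ethyl. Among the measured compounds shown here, no measured pair shows such a change, so no step beyond the scatter is expected in this assay. The expected step is a 1.1-fold lower number from compound 3 to compound 4 (0.04 log units; within the scatter). For compound 4 the estimated value is 2400 ng.h/mL, with an expected range from 1000 ng.h/mL to 6000 ng.h/mL.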

Compound 4, area under the concentration-time curve: 1650 ng.h/mL
Compound 4: middle estimate off by 1.5-fold (0.16 log units), on the high side; measured number inside the range.
By their numbers in this assay, from the lowest: compounds 4 and 3 (each within the scatter of the next); then compounds 2 and 1 (each within the scatter of the next).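

In this assay, among the compounds shown here, the change from methyl to ethyl on a saturated chain carbon bound to an aromatic carbon gives a 1.6-fold lower number from compound 3 to compound 4 (0.20 log units; within the scatter) and so provides the first step between compounds that differ in one place. At this position the added methyl therefore moves exposure by no more than the usual scatter. Nothing measured here explains this result. As far as these compounds go, whether a longer chain such as propyl, a branched chain such as isopropyl, or an amine at this position would give a step beyond the scatter remains open.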